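A few compounds are considered here, and "the series" means these few. Any claim that something is new, unique, unknown or untested is made for them only; others in the source may bear on it.

Going by the values given here, in a functional assay on HCT-116 cells (Homo sapiens) for antiproliferative activity, with a stated time of 72 h (on this read-out lower numbers stand for stronger inhibition and higher numbers for weaker inhibition), compound 1 (`COc1ccccc1/C=C/c1nc(Nc2cccc(O)c2)c2ccccc2n1`) gives 21700 nM and compound 2 (`COc1ccc(/C=C/c2nc(Nc3cccc(O)c3)c3ccccc3n2)cc1`) gives 22900 nM, so compound 2 stands level with its only neighbour, within the scatter. Compound 3 (`O=[N+]([O-])c1cccc(/C=C/c2nc(Nc3cccc(O)c3)c3ccccc3n2)c1`) follows, with 3-nitrophenyl in place of 4-methoxyphenyl on a double-bonded chain carbon bound to a double-bonded chain carbon. Among the compounds with values here, the one measured step bearing on this is a 1.1-fold higher number from compound 1 to compound 2 (0.02 log units; within the scatter), for 4-methoxyphenyl in place of 2-methoxyphenyl. Within the data shown here, no measured compound carries a nitro group, so the evidence is thin and no shift beyond the scatter is expected. The expected move in this assay is a 1.3-fold lower number from compound 2 to compound 3 (0.10 log units; within the scatter). Compound 3 is estimated at 18000 nM, with an expected range of 6000 nM to 45000 nM.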

Compound 3, half-maximal inhibitory concentration: 10900 nM
The estimate for compound 3 lay 1.7-fold (0.22 log units) above the measured number; the range from low to high includes it.
By their numbers in this assay, from the lowest: compounds 3, 1 and 2 (each within the scatter of the next, the first and the last beyond it).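

In this assay, going by these compounds alone, this place on a double-bonded chain carbon bound to a double-bonded chain carbon now responds to the group it carries: 3-nitrophenyl in place of 4-methoxyphenyl gives a 2.1-fold lower number from compound 2 to compound 3 (0.32 log units; beyond the scatter), the only step beyond the scatter, and a modest one. Against 2-methoxyphenyl, the same group gives a 2.0-fold lower number from compound 1 to compound 3 (0.30 log units; within the scatter), which stays within the scatter. No measurement on hand explains the step. The compounds shown do not separate the nitro group from its place on the ring, which 4-nitrophenyl or 3-methoxyphenyl could do. Going by these compounds, whether an amine or a carboxylic acid on this ring would shift the number also remains open.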